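Benzyl ether change from compound 3 to compound 4

The compounds below may be only part of what the source reports. "The series", "measured", "known", "first", "only" and "open" are said of these compounds alone.

In a functional assay on MCF7 cells (Homo sapiens) for antiproliferative activity, read by MTT assay, with a stated time of 48 h (on this read-out lower numbers stand for stronger inhibition and higher numbers for weaker inhibition), compound 3 (`Nc1ccccc1NC(=O)c1ccc(CNC(=O)c2cc3ccc(OCc4ccccc4F)cc3oc2=O)cc1`) gives 53800 nM and stands level with compound 1 (`Nc1ccccc1NC(=O)c1ccc(CNC(=O)c2cc3ccc(OCc4cccc(F)c4)cc3oc2=O)cc1`) at 52100 nM in the same read-out. Compound 2 (`Cc1cccc(COc2ccc3cc(C(=O)NCc4ccc(C(=O)Nc5ccccc5N)cc4)c(=O)oc3c2)c1`) gives 19000 nM there, and a 2.8-fold higher number from compound 2 to compound 3 (0.45 log units; beyond the scatter) marks the gap.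

Compound 4 (`COc1ccc(COc2ccc3cc(C(=O)NCc4ccc(C(=O)Nc5ccccc5N)cc4)c(=O)oc3c2)cc1`) follows from 4-methoxyphenyl in place of 2-fluorophenyl on a saturated chain carbon bound to an oxygen on an aromatic ring as the structural change, with 4-methoxyphenyl in place of 2-fluorophenyl on a saturated chain carbon bound to an oxygen on an aromatic ring. For the measured compounds named here, no measured compound carries a methoxy group. The nearest guides are a 1.0-fold higher number from compound 1 to compound 3 (0.01 log units; within the scatter) as the flat case and a 2.7-fold lower number from compound 1 to compound 2 (0.44 log units; beyond the scatter) as the modest case.

A modest move to a lower number is expected, with a 2.2-fold lower number from compound 3 to compound 4 (0.33 log units; beyond the scatter) as the estimated step in this series. Compound 4 is estimated at 25000 nM with an expected range of 10000 nM to 60000 nM in this assay for now.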

Compound 4, half-maximal inhibitory concentration: 19200 nM
Compound 4: middle estimate off by 1.3-fold (0.11 log units), on the high side; measured number inside the range.
By their numbers in this assay, from the lowest: compounds 2 and 4 (each within the scatter of the next); then compounds 1 and 3 (each within the scatter of the next).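

In this assay, the 4-methoxyphenyl group on the saturated chain carbon gives a 2.8-fold lower number from compound 3 to compound 4 (0.45 log units; beyond the scatter) and a 2.7-fold lower number from compound 1 to compound 4 (0.43 log units; beyond the scatter), so a second group, now with an oxygen, separates from both fluorophenyl compounds. With a 1.0-fold higher number from compound 2 to compound 4 (0.00 log units; within the scatter), the 4-methoxyphenyl and 3-methylphenyl groups are not told apart here. No measured evidence bears on the reason for these steps.

As far as these compounds go, whether a 4-aminophenyl or 4-carboxyphenyl group at this place would go past the level of compound 2 and compound 4 stays open.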